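Swapping the Aryl Group on a Caffeine-Derived Ester

The compounds below may be only part of what the source reports. "The series", "measured", "known", "first", "only" and "open" are said of these compounds alone.

Compound 1 `COC(C(=O)OC(C)Cn1cnc2c1c(=O)n(C)c(=O)n2C)c1cccc2ccccc12` was tested in a functional assay on MCF7 cells (Homo sapiens) for antiproliferative activity, read by MTT assay, with a stated time of 72 h, tested at 100 uM (on this read-out higher numbers stand for a weaker effect at the one concentration tested and lower numbers for a stronger effect), where compound 1 gives 83.3%. Among the three measured compounds this is the second highest number: compound 3 `CC(Cn1cnc2c1c(=O)n(C)c(=O)n2C)OCc1cn(-c2cccc3ccccc23)nn1` gives 93.3%, a number within the scatter of compound 1, while compound 2 `CC(Cn1cnc2c1c(=O)n(C)c(=O)n2C)OCc1cn(CCCn2nc3c(Br)c(Br)c(Br)c(Br)c3n2)nn1` gives 59.1%, a number beyond the scatter below compound 1. Compound 4 `COC(C(=O)OC(C)Cn1cnc2c1c(=O)n(C)c(=O)n2C)c1ccc(C(C)(C)C)cc1` has not been measured. It differs from compound 1 by 4-(tert-butyl)phenyl in place of naphthalen-1-yl on a saturated chain carbon bound to a carbonyl carbon and an oxygen on a saturated carbon, the entering group carrying one six-membered aromatic ring of carbon only where the leaving group carried two. Within the data shown here, no measured pair of this kind exists to compare, so the step of a number 1.7 percentage points higher from compound 1 to compound 4 (within the scatter) is expected to stay within the scatter, in no clear direction. Compound 4 is accordingly estimated at 85%, ranging from 65% to 100%.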

Compound 4, a percentage reported as activity, at one concentration (the size of the read-out at that concentration, not a potency): 63.5%
Compound 4: middle estimate off by 21.5 percentage points, on the high side, and the stated range ends above it.
By their numbers in this assay, from the lowest: compounds 2 and 4 (each within the scatter of the next); then compounds 1 and 3 (each within the scatter of the next).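

At the saturated chain carbon bound to a carbonyl carbon and an oxygen on a saturated carbon, the aryl group can shift the read-out: in this assay 4-(tert-butyl)phenyl in place of naphthalen-1-yl gives a number 19.8 percentage points lower from compound 1 to compound 4 (beyond the scatter) and so a stronger effect at the one concentration tested. The shift comes with no change in the count of heavy atoms, while one six-membered aromatic ring of carbon only stands where two stood. No measurement shown accounts for this shift.

As far as these compounds go, whether the step follows the tert-butyl group or the loss of the second ring remains open. A plain phenyl, or a phenyl carrying an amine or a carboxylic acid, could help separate the two.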